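The source may hold more compounds than are shown below. What is called first, only, known or untested is meant among the compounds shown, and "the series" means these compounds.

Measured in a toxicity assay on NIH3T3 cells (Mus musculus) for cytotoxicity, read by resazurin assay (a lower number here means that less compound is needed, a higher number that more compound is needed for the effect), each value a limit:
- compound 1 `N#Cc1ccc(NCc2cncn2Cc2ccc(-c3ccccc3)cc2)cc1-c1ccccc1`: > 1000 nM
- compound 2 `c1ccc(-c2ccc(Cn3cncc3CNc3ccc(-c4cncs4)c(-c4ccccc4)c3)cc2)cc1`: > 1000 nM
- compound 3 `CC(C)OC(=O)c1ccc(NCc2cncn2Cc2ccc(-c3ccccc3)cc2)cc1-c1ccccc1`: > 10000 nM

Compound 3 stands at the limit > 10000 nM, and no number is known for it. Among the compounds with values here, this is the only value of its kind in the set (the limit of > 10000 nM in this assay, at which 1 of the 3 values shown sits); the other two share a separate limit (the limit of > 1000 nM in this assay, at which 2 of the 3 values shown sit). Compound 4 `c1ccc(-c2ccc(Cn3cncc3CNc3ccc(N4CCCC4)c(-c4ccccc4)c3)cc2)cc1` carries pyrrolidin-1-yl in place of isopropoxycarbonyl on an aromatic carbon.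

The measured steps that bear on this change are those at the same aromatic carbon: a step that the two limits leave unreadable from compound 1 to compound 3, a step that the two limits leave unreadable from compound 2 to compound 3 and a step that the two limits leave unreadable from compound 1 to compound 2. None has a readable size, so the size of any step in this assay rests on limits alone. Compound 1 and compound 2 show only that no effect was reached within their limits, so a number for compound 4 is expected late in the range, if one is obtained at all. A limit is the likeliest report. A modest shift toward less compound needed is expected, giving an at least 2.0-fold lower number from compound 3 to compound 4 (0.30 log units; that floor lies within the scatter). For compound 4 the estimate is 5000 nM, with an expected range of 1000 nM to 20000 nM.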

Compound 4, half-maximal effective concentration: > 1000 nM
Compound 4 ended at the assay's limit (the forecaster's own chance of this, stated with the estimate: 65%); the middle value lies beyond the limit too.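

In this assay compound 4 gives > 1000 nM, a limit and not a number. Within the data shown here, no step from compound 1, compound 2 or compound 3 to compound 4 can be read. The compounds shown leave open whether the groups at this aromatic carbon differ in cytotoxicity at all.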